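Benzyl-amine variation on a diamino core in a cell growth assay

The source may hold more compounds than are shown below. What is called first, only, known or untested is meant among the compounds shown, and "the series" means these compounds.

Working notes on the series. Compound 1 `Nc1cc(N)c2nc(-c3ccccc3)c(NCc3ccc(Cl)c(Cl)c3)nc2c1` and compound 2 `CCOC(=O)[C@H](CCC(=O)O)NC(=O)c1ccc(Sc2nc3cc(N)cc(N)c3nc2-c2ccccc2)cc1` share the diamino core and differ at the side chain. In a functional assay on SF-295 cells (Homo sapiens) for inhibition, read by sulforhodamine B assay, with a stated time of 48 h (a higher number here means a weaker inhibitor of growth, a lower number a stronger inhibitor of growth), compound 1 gives 15500 nM; compound 2 gives 25100 nM in this assay. The two numbers lie within the usual scatter of one another, so neither can be placed above the other. Within the data shown here, no pair of measured compounds differs in one place, so no measured step is available.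

Compound 3 `COc1ccc(CNc2nc3cc(N)cc(N)c3nc2-c2ccccc2)cc1` is the unmeasured member: 4-methoxyphenyl in place of 3,4-dichlorophenyl on a saturated chain carbon bound to a nitrogen on an aromatic ring. Without a measured step to rest on, the change is expected to move the number in this assay by no more than the scatter, in no firm direction, so the step of a 1.3-fold higher number from compound 1 to compound 3 (0.11 log units; within the scatter) is expected to be small. For compound 3 the value in this assay is estimated at 20000 nM, with a range from 6000 nM to 60000 nM.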

Compound 3, concentration for 50% growth inhibition: 17800 nM
The estimate for compound 3 lay 1.1-fold (0.05 log units) above the measured number; low and high end bracket the measured number.
By their numbers in this assay, from the lowest: compounds 1, 3 and 2 (each within the scatter of the next).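

In this assay, among these compounds, 4-methoxyphenyl in place of 3,4-dichlorophenyl on a saturated chain carbon bound to a nitrogen on an aromatic ring gives a 1.1-fold higher number from compound 1 to compound 3 (0.06 log units; within the scatter), the only measured step so far. Among the compounds shown here, at this position, then, two groups with different atoms and with hydrogen-bond acceptor counts of 0 and 1 cannot be told apart in this assay, which the earlier compounds, differing at the side chain as a whole, could not show. No accompanying measurement bears on this result.

From the compounds shown here alone, whether a carboxylic acid or an amine on the phenyl ring would carry the number in this assay beyond the scatter remains open. Also open, going by these compounds, is what a longer chain in place of the single saturated chain carbon would do.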